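A few compounds are considered here, and "the series" means these few. Any claim that something is new, unique, unknown or untested is made for them only; others in the source may bear on it.

Measured in an ADME assay on MT4 cells (Homo sapiens) for cytotoxicity, read by MTT assay; on this read-out higher numbers stand for lower toxicity in this test and lower numbers for higher toxicity in this test:
- Compound 1 `Cc1cc(C)cc(CSc2nc(Cc3c(F)cccc3F)c(C)c(=O)[nH]2)c1`: > 65000 nM (a limit)
- Compound 2 `Cc1c(Cc2c(F)cccc2F)nc(SCc2ccccn2)[nH]c1=O`: > 70000 nM (a limit)

Compound 2 has no exact value, only its limit of > 70000 nM. Compound 1 is likewise known only by a limit, > 65000 nM. Going by the values given here, the one measured step, a step that the two limits leave unreadable from compound 1 to compound 2, places pyridin-2-yl where 3,5-dimethylphenyl stood on a saturated chain carbon bound to a sulfur.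

Compound 3 `Cc1c(Cc2c(F)cccc2F)nc(SCc2ccncc2)[nH]c1=O` keeps that position but has pyridin-4-yl in place of pyridin-2-yl on a saturated chain carbon bound to a sulfur. The two have the same atoms, joined differently. The step that the two limits leave unreadable from compound 1 to compound 2 offers no size to carry over, so no change beyond the scatter is expected in this assay. The expected step is a number no higher from compound 2 to compound 3 (the limit leaves the size open). Compound 3 is estimated at 70000 nM, with an expected range from 25000 nM to 120000 nM.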

Compound 3, half-maximal cytotoxic concentration: > 70000 nM
Compound 3: only a limit was reported (the forecaster's own chance of this, stated with the estimate: 80%); the middle value lies on the limit itself.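

No step can be read among compound 1, compound 2 and compound 3, as all three are known only by limits in this assay. The compounds shown leave open whether 3,5-dimethylphenyl, pyridin-2-yl and pyridin-4-yl on a saturated chain carbon bound to a sulfur differ in cytotoxicity at all.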